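This account rests on a few compounds, and the source may have more. Where it says the series, first, only, none or still open, it means among the compounds named here.

Measured so far:
- compound 1 `CN(C)c1ccc2c(=O)c(C(=O)Nc3cc(F)cc(F)c3)cn(-c3ccc(OCCCCCCC[N+]4(C)CCCCC4)cc3F)c2n1`: "not active" (no number reported)
- compound 2 `Cc1cc(OCCCCCCC[n+]2ccccc2)ccc1-n1cc(C(=O)Nc2cc(F)cc(F)c2)c(=O)c2ccc(N(C)C)nc21`: "not active" (no number reported)
- compound 3 `CN(C)c1ccc2c(=O)c(C(=O)Nc3cc(F)cc(F)c3)cn(-c3ccc(OCCCCCCC[n+]4ccccc4)cc3F)c2n1`: 15.4%

Going by the values given here, in an assay on LX2 cells for inhibition of COL1A1 promoter (Homo sapiens), read by a luciferase reporter, with a stated time of 24 h, tested at 20 uM (a higher number here means a stronger effect of the compound at the concentration tested, a lower number a weaker effect), compound 3 gives 15.4% and is the only compound with a number; compound 1 and compound 2 were reported without one. Compound 4 `CN1CC[N+](C)(CCCCCCCOc2ccc(-n3cc(C(=O)Nc4cc(F)cc(F)c4)c(=O)c4ccc(N(C)C)nc43)c(F)c2)CC1` has not been measured. It differs from compound 3 as follows (a group of 8 heavy atoms (6 carbon, 2 nitrogen; one six-membered non-aromatic ring with 2 hetero atoms) in place of a group of 6 heavy atoms (5 carbon, 1 nitrogen; one six-membered aromatic ring with 1 hetero atom), on a saturated chain carbon, seven bonds along the chain from an oxygen on an aromatic ring). Among the compounds with values here, with no measured pair of this kind, the size of the step is uncertain; since compound 1, which also carries a non-aromatic ring group at this place, gives "not active" (no number reported), the expectation leans toward a small loss or none beyond the scatter. For compound 4 the expected result in this assay is 10%, with a range from 0% to 25%; the expected step of a number 5.4 percentage points lower from compound 3 to compound 4 (within the scatter) is small.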

Compound 4, a percentage reported as inhibition, at one concentration (the size of the read-out at that concentration, not a potency): "not active" (no number reported)
For compound 4 the study gives words and no number, so the estimate cannot be set against anything.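

In this assay, going by these compounds alone, compound 4 gives "not active" (no number reported) and so no step from compound 3 to compound 4 can be read. No supporting measurement bears on this result. The compounds shown leave open how much the ring group on the saturated chain carbon changes the effect, with only compound 3 carrying a number.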